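The source may hold more compounds than are shown below. What is called first, only, known or untested is meant among the compounds shown, and "the series" means these compounds.

Notes on the series. All compounds share one core and differ only on the sulfonamide nitrogen. Compound 1 `CCN(CC)C(=O)CN(c1ccc(C)cc1)S(=O)(=O)c1ccc(OC)c(OC)c1` carries a 4-methylphenyl there; in a functional assay on CHO cells for inhibition of Orexin/Hypocretin receptor type 1 (Homo sapiens), read by FLIPR and calcium flux (a higher number here means a weaker inhibitor, a lower number a stronger inhibitor), compound 1 gives only the limit > 10000 nM. Compound 2 `CCN(CC)C(=O)CN(c1cccc(N(C)C)c1C#N)S(=O)(=O)c1ccc(OC)c(OC)c1` carries a 2-cyano-3-(dimethylamino)phenyl instead; in this assay compound 2 likewise gives only the limit > 10000 nM. Compound 3 `CCN(CC)C(=O)CN(c1cc(N(CC)CC)ccc1Cl)S(=O)(=O)c1ccc(OC)c(OC)c1` in this assay also gives only the limit > 10000 nM. The step that the two limits leave unreadable from compound 1 to compound 2 therefore cannot be read. Compound 2 thus stands at the limit shared by every measured value (the limit of > 10000 nM in this assay, at which 3 of the 3 values shown sit). Compound 4 `CCN(CC)C(=O)CN(c1cc2c(C)nsc2cc1Cl)S(=O)(=O)c1ccc(OC)c(OC)c1` differs from compound 2 by a group of 11 heavy atoms (8 carbon, 1 nitrogen, 1 sulfur, 1 chlorine; one five-membered aromatic ring with 2 hetero atoms, one six-membered aromatic ring of carbon only) in place of a group of 11 heavy atoms (9 carbon, 2 nitrogen; one six-membered aromatic ring of carbon only), on a sulfonamide nitrogen. Within the data shown here, no measured step bears on this change with a readable size, so the data give no direction. Compound 4 is expected at 10000 nM, range 3000 nM to 30000 nM, most probably again a limit. The step of a number no higher from compound 2 to compound 4 (the limit leaves the size open) is accordingly estimated as nothing readable.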

Compound 4, half-maximal inhibitory concentration: 29 nM
Beside the measured number, compound 4's estimate is 340-fold (2.54 log units) above it; the measured number lies below the stated range.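

The sulfonamide nitrogen substituent, which had shown nothing readable, can carry activity: in this assay the bicyclic group gives an at least 340-fold lower number from compound 2 to compound 4 (2.53 log units; beyond the scatter), with the heavy-atom count unchanged. Against the smaller 4-methylphenyl, the same group gives an at least 340-fold lower number from compound 1 to compound 4 (2.53 log units; beyond the scatter). Among these compounds, all other steps cannot be read, and compound 4 is the only compound off the limit: the limit of > 10000 nM in this assay, at which 3 of the 4 values shown sit.

The compounds shown leave open whether the step depends on the chlorine or on the five-membered aromatic ring. They also leave open whether a bromine in place of the chlorine would keep it.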